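The compounds below may be only part of what the source reports. "The series", "measured", "known", "first", "only" and "open" are said of these compounds alone.

Working notes on the series.

Compound 1 `CCCc1nc(-c2ccccc2)c(CNCCCN2CCN(c3ccccc3F)CC2)o1` is the weakest of the three measured compounds in an assay on HEK293 cells for inhibition of Voltage-dependent T-type calcium channel subunit alpha-1G (Homo sapiens), read by patch clamp (on this read-out higher numbers stand for weaker inhibition and lower numbers for stronger inhibition), with compound 1 giving 16100 nM. Compound 2 `CCCc1nc(-c2ccccc2)c(CNCCN2CCN(c3cccc(C(F)(F)F)c3)CC2)o1` gives 1940 nM and compound 3 `CCCc1nc(-c2ccccc2)c(CNCCN2CCN(c3ccccc3C)CC2)o1` gives 4300 nM; both carry a shorter chain between the two amine nitrogens than compound 1, so neither is a single-point comparison to it.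

Compound 4 `CCCc1nc(-c2ccccc2)c(CNCCCN2CCN(c3cccc(F)c3)CC2)o1` differs from compound 1 in one place: 3-fluorophenyl in place of 2-fluorophenyl on an amine nitrogen in a ring.

Among the compounds with values here, the only measured step that touches the aryl group on the ring nitrogen is a 2.2-fold higher number from compound 2 to compound 3 (0.35 log units; beyond the scatter). There the group moved from a 3-position to a 2-position, with a modest rise in the number. The change to compound 4 runs the opposite way, from a 2-position to a 3-position, and also swaps nothing but the fluorine's place. Within the data shown here, the expectation is a modest fall, roughly the size of that step, but with wide uncertainty, because only one step, a 2.2-fold higher number from compound 2 to compound 3 (0.35 log units; beyond the scatter), informs it and it involves different groups.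

Compound 4 is therefore expected to give 6500 nM, likely between 2500 nM and 16000 nM, a step of a 2.5-fold lower number from compound 1 to compound 4 (0.39 log units; beyond the scatter).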

Compound 4, half-maximal inhibitory concentration: 3030 nM
Compound 4: middle estimate off by 2.1-fold (0.33 log units), on the high side; measured number inside the range.
By their numbers in this assay, from the lowest: compounds 2, 4 and 3 (each within the scatter of the next, the first and the last beyond it); then compound 1.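

Within the data shown here, with the atoms unchanged and only the fluorine moved, 3-fluorophenyl in place of 2-fluorophenyl gives a 5.3-fold lower number from compound 1 to compound 4 (0.73 log units; beyond the scatter), the first single-change reading at this aryl group on the longer chain of compound 1. The direction agrees with a 2.2-fold higher number from compound 2 to compound 3 (0.35 log units; beyond the scatter): in both listed steps, the compound bearing the 3-substituted phenyl has the lower number, although the groups in that earlier step are 3-(trifluoromethyl)phenyl and 2-methylphenyl rather than fluorophenyl groups. No measurement available here bears on the origin of this shift.

The effect of chain length remains unreadable, as compounds 2 and 3 each differ from compounds 1 and 4 in more than one place. Going by these compounds, it also remains open how unsubstituted phenyl, or a chlorine in place of the fluorine, would read in this assay.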